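The source may report more compounds than this note shows. Statements on the series, on what has been measured and on what is new or still open speak of the compounds shown alone.

The measurements come from an ADME assay on MRC5 cells (Homo sapiens), read by MTT assay, with a stated time of 72 h; a higher number here means a weaker inhibitor, a lower number a stronger inhibitor. Compound 2 `O=c1[nH]cnc2c1c(-c1cc3ccccc3o1)cn2[C@@H]1O[C@H](CO)[C@@H](O)[C@H]1O` carries a 1-benzofuran-2-yl group on an aromatic carbon of a five-membered aromatic ring with one nitrogen, part of a fused system of two rings. In this assay compound 2 reaches only the limit of > 100000 nM, so no number is known for it. It does not stand alone there, since the limit of > 100000 nM in this assay, at which 2 of the 3 values shown sit, marks where compound 2 sits. Compound 1 `CNc1ncnc2c1c(-c1ccccc1)cn2[C@@H]1O[C@H](CO)[C@@H](O)[C@H]1O` also stops at the limit, giving > 100000 nM in this assay. For the measured compounds named here, compound 3 `COc1ncnc2c1c(-c1ccoc1)cn2[C@@H]1O[C@H](CO)[C@@H](O)[C@H]1O` is the one compound with a number, giving 29400 nM in this assay.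

Compound 4 `O=c1[nH]cnc2c1c(-c1ccco1)cn2[C@@H]1O[C@H](CO)[C@@H](O)[C@H]1O` is not yet measured. It differs from compound 2 in one place: furan-2-yl in place of 1-benzofuran-2-yl on an aromatic carbon. The rest of the molecule is kept unchanged. Going by the values given here, no measured pair shows this change on its own, so the size of the step has to be estimated. The expected step of an at least 1.1-fold lower number from compound 2 to compound 4 (0.04 log units; that floor lies within the scatter) is taken as none beyond the scatter, starting from a limit. Compound 4 is therefore expected to give about 90000 nM in this assay, with a range from 25000 nM to 250000 nM, and it may again stop at the limit.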

Compound 4, half-maximal inhibitory concentration: > 100000 nM
Compound 4 gave a limit, no number; the forecaster's own chance of this, stated with the estimate: 60%; middle value at least 1.1-fold (0.04 log units) away from the limit.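

Compound 2 and compound 4 both stop at a limit in this assay, and no size can be read for the step between them. The compounds shown leave open what number either compound would give, and whether furan-2-yl in place of 1-benzofuran-2-yl changes anything here.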